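From Ethoxy to Methoxy: An Expected Flat Step

This account rests on a few compounds, and the source may have more. Where it says the series, first, only, none or still open, it means among the compounds named here.

Two measured compounds share one core and differ only in the group on an aromatic carbon. Compound 1 `Cc1ccc2nc(C(=O)Nc3c(F)cc(-c4cccc(F)c4)cc3F)c(C)c(C(=O)O)c2c1` carries a methyl there; in a functional assay on A-375 cells (Homo sapiens) for antiproliferative activity, read by MTT assay, with a stated time of 24 h, tested at 0.05 ug/mL (on this read-out lower numbers stand for a weaker effect and higher numbers for a stronger effect at the one concentration tested), compound 1 gives 0.35%. Compound 2 `CCOc1ccc2nc(C(=O)Nc3c(F)cc(-c4cccc(F)c4)cc3F)c(C)c(C(=O)O)c2c1` carries an ethoxy in its place, and in this assay compound 2 gives 1.96%. Among the compounds with values here, the single step among the measured pairs, a number 1.6 percentage points higher from compound 1 to compound 2 (within the scatter), lies within the scatter, so the numbers of compound 2 and compound 1 cannot be told apart; both sit close to no effect at the concentration tested.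

Compound 3 `COc1ccc2nc(C(=O)Nc3c(F)cc(-c4cccc(F)c4)cc3F)c(C)c(C(=O)O)c2c1` is reached from compound 2 by one change: hydrogen in place of methyl on a saturated chain carbon bound to an oxygen on an aromatic ring. Within the data shown here, no measured step covers this exact change, but the only step that involves the ethoxy group, a number 1.6 percentage points higher from compound 1 to compound 2 (within the scatter), was small, and neither measured compound showed more than a trace of inhibition. Compound 3 is therefore expected to stay at the same low level, with a step of a number 0.5 percentage points lower from compound 2 to compound 3 (within the scatter) in this assay that is not beyond the scatter. The estimate for compound 3 is 1.5%, within a range from -4% to 8%.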

Compound 3, a percentage reported as inhibition, at one concentration (the size of the read-out at that concentration, not a potency): 1.05%
The estimate for compound 3 lay 0.5 percentage points above the measured number, within the range that was stated.
By their numbers in this assay, from the lowest: compounds 1, 3 and 2 (each within the scatter of the next).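

Going from ethoxy to methoxy, which removes the methyl on the saturated chain carbon bound to an oxygen on an aromatic ring, gives a number 0.9 percentage points lower from compound 2 to compound 3 (within the scatter) in this assay, so the two chain lengths cannot be told apart here. The earlier compounds shown here compared only ethoxy with methyl on the aromatic carbon, whereas methoxy in place of methyl at that carbon now gives a second such comparison, a number 0.7 percentage points higher from compound 1 to compound 3 (within the scatter), and methyl, methoxy and ethoxy all stay near no effect with no difference that can be read among them. No measurement is available that explains these numbers or accounts for the lack of a readable difference among the three groups.

Because all three compounds lie so close to no effect at the single concentration tested, the flat result cannot show whether these groups would separate at another concentration. It also leaves open whether an amine, a carboxylic acid or a longer chain such as butoxy on this aromatic carbon would lift the read-out clear of this low level.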